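The source may report more compounds than this note shows. Statements on the series, on what has been measured and on what is new or still open speak of the compounds shown alone.

Measured so far:
compound 1, `COc1cc(OC)c(OC)cc1/C=C/COC(=O)/C=C/c1cccc(Br)c1`, in a functional assay on the whole organism (strain Kunming) with Mus musculus as the target, with a stated time of 0.5 h, at a dose of 300 mg/kg by the intraperitoneal route (on this read-out higher numbers stand for a weaker effect at the one dose given and lower numbers for a stronger effect), gives 25%
compound 2, `COc1cccc(/C=C/C(=O)OC/C=C/c2cc(OC)c(OC)cc2OC)c1`, in this assay gives 50%

On the two numbers shown, compound 2 stands highest in this assay; its nearest neighbour is compound 1, and the step of a number 25 percentage points higher from compound 1 to compound 2 (beyond the scatter) lies beyond the scatter.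

Compound 3, `COc1ccc(/C=C/C(=O)OC/C=C/c2cc(OC)c(OC)cc2OC)cc1`, has not yet been measured. It differs from compound 2 in one place: 4-methoxyphenyl in place of 3-methoxyphenyl on a double-bonded chain carbon bound to a double-bonded chain carbon. Among the measured compounds shown here, the only measured step, a number 25 percentage points higher from compound 1 to compound 2 (beyond the scatter), exchanges bromo for methoxy and so does not bear on a move of the methoxy group from one carbon of the ring to another; it shows only that a change at this aromatic ring can shift the read-out in this assay by a modest amount. For the measured compounds named here, no measured pair tells how much the position of the methoxy group matters. For the step from compound 2 to compound 3 a change within the scatter is therefore expected, with a slight lean toward a lower number, a number 5 percentage points lower from compound 2 to compound 3 (within the scatter). For compound 3 the estimate in this assay is 45%, between 25% and 70%.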

Compound 3, a percentage reported as activity, at one dose (the size of the read-out at that dose, not a potency): 0%
Estimate against measurement, compound 3: 45 percentage points above; the measured number lies below the stated range.
By their numbers in this assay, from the lowest: compound 3; then compound 1; then compound 2.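

In this assay, 4-methoxyphenyl in place of 3-methoxyphenyl gives a number 50 percentage points lower from compound 2 to compound 3 (beyond the scatter), so with the same atoms joined differently, where the methoxy group sits on this ring alone changes the read-out by a large amount, more than the exchange of bromo for methoxy had shown. Set against the 3-bromophenyl group, the 4-methoxyphenyl group gives a number 25 percentage points lower from compound 1 to compound 3 (beyond the scatter), and as both steps lie beyond the scatter, compound 3 shows the strongest effect of the three at the one dose given, although that read-out is not a potency. Nothing available explains why this change of position has so large an effect.

The compounds shown leave open whether the bromo group would respond to the same change of position as the methoxy group does, so the result cannot yet be taken as a rule for this ring. They also leave open how a dimethylamino group or a carboxylic acid would fare in place of the methoxy group, and whether an amide linkage could stand in for the ester of the shared core.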